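This account rests on a few compounds, and the source may have more. Where it says the series, first, only, none or still open, it means among the compounds named here.

Compound 1 `CCNC(=O)c1noc(-c2cc(C(C)C)c(O)cc2O)c1-c1cc(COCC(N)=O)no1` has "not determined" (no result reported) in a functional assay on A2780 cells (Homo sapiens) for inhibition; on this read-out higher numbers stand for weaker inhibition and lower numbers for stronger inhibition. Within the data shown here, compound 2 `CCNC(=O)c1noc(-c2cc(C(C)C)c(O)cc2O)c1-c1cc(CNC(C)C)no1` gives 38 nM in this assay, and this is the only number in hand for the series, so compound 2 stands alone as its point of reference. Compound 3 `CCNC(=O)c1noc(-c2cc(C(C)C)c(O)cc2O)c1-c1cnn(CC)c1` differs from it by the change 1-ethyl-1H-pyrazol-4-yl in place of 3-((isopropylamino)methyl)-1,2-oxazol-5-yl on an aromatic carbon on the shared core. Among the measured compounds shown here, no measured step of this kind exists, so the direction and size can only be expected: the entering group brings no hydrogen-bond donor, and a move toward weaker inhibition somewhat beyond the usual scatter is expected, a 2.9-fold higher number from compound 2 to compound 3 (0.46 log units; beyond the scatter). Compound 3 is accordingly estimated at 110 nM, within a range from 35 nM to 350 nM.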

Compound 3, half-maximal inhibitory concentration: 30 nM
Compound 3: the middle estimate sits 3.7-fold (0.56 log units) above what was measured; the whole stated range lies above it.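

In this assay the exchange on this aromatic carbon gives a 1.3-fold lower number from compound 2 to compound 3 (0.10 log units; within the scatter) and so separates compound 2 from compound 3 by no real margin. This position therefore takes 1-ethyl-1H-pyrazol-4-yl as well as 3-((isopropylamino)methyl)-1,2-oxazol-5-yl, and the hydrogen-bond donor of the leaving group is not needed for a value of this size. No evidence at hand accounts for this result.

Steps involving compound 1 cannot be read. Going by these compounds, whether a longer chain or an amine in place of the ethyl of 1-ethyl-1H-pyrazol-4-yl would hold this level stays open.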